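A Second Methoxy Group on the Arylamine of Compound 1

A few compounds are considered here, and "the series" means these few. Any claim that something is new, unique, unknown or untested is made for them only; others in the source may bear on it.

The two measured compounds share a core and differ in several places at once. Compound 1 `C=C1[C@@H](OC(C)=O)C[C@@H]2[C@](C)(CO[Si](C)(C)C(C)(C)C)[C@H](OC(C)=O)CC[C@@]2(C)[C@@H]1C[C@@H](Nc1ccc(OC)cc1)C1=CCOC1=O` stands lowest of the two numbers in a functional assay on MCF7 cells (Homo sapiens) for cytotoxicity, read by sulforhodamine B assay (a lower number here means a stronger inhibitor, a higher number a weaker inhibitor), at 4280 nM. Among the measured compounds shown here, compound 2 `C=C1[C@@H](OC(C)=O)C[C@@H]2[C@](C)(COC=O)[C@H](OC(C)=O)CC[C@@]2(C)[C@@H]1C[C@@H](Nc1ccc(F)cc1)C1=CCOC1=O` gives 12400 nM in this assay, a higher number beyond the usual scatter, but since the structures differ in more than one place, no single step can be drawn between them. Compound 3 `C=C1[C@@H](OC(C)=O)C[C@@H]2[C@](C)(CO[Si](C)(C)C(C)(C)C)[C@H](OC(C)=O)CC[C@@]2(C)[C@@H]1C[C@@H](Nc1ccc(OC)c(OC)c1)C1=CCOC1=O` differs from compound 1 in one place: methoxy in place of hydrogen on an aromatic carbon. For the measured compounds named here, no measured pair isolates this change, so the data give no guide to its size. One expects a step of a 1.1-fold lower number from compound 1 to compound 3 (0.03 log units; within the scatter), which is not beyond the scatter in either direction. Compound 3 is therefore estimated at 4000 nM in this assay, with a range from 1500 nM to 12000 nM.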

Compound 3, half-maximal inhibitory concentration: 4310 nM
The estimate for compound 3 lay 1.1-fold (0.03 log units) below the measured number; the measured number falls inside the stated range.
By their numbers in this assay, from the lowest: compounds 1 and 3 (each within the scatter of the next); then compound 2.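

In this assay, among the compounds shown here, methoxy in place of hydrogen on this aromatic carbon, ortho to a methoxy group and meta to a large group, gives a 1.0-fold higher number from compound 1 to compound 3 (0.00 log units; within the scatter) and so supplies the first step that isolates a single change. On this evidence, the 4-methoxyphenyl and 3,4-dimethoxyphenyl forms cannot be told apart in this assay, and this position takes the added methoxy without a step beyond the scatter. Nothing at hand explains why the added group leaves the number within the scatter.

Going by these compounds, whether a hydroxyl group, an amine or a carboxylic acid on this same aromatic carbon would also stay within the scatter remains open. So does the outcome of replacing the new methoxy with a longer chain such as ethoxy or butoxy.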